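Halogenated benzyl ether replaces the nitrile in compound 4

A few compounds are considered here, and "the series" means these few. Any claim that something is new, unique, unknown or untested is made for them only; others in the source may bear on it.

Measured compounds:
compound 1 `O=C(NCc1ccco1)c1ccccc1OCc1ccccc1`: 49000 nM
compound 2 `O=C(Nc1ccccn1)c1ccccc1OCc1ccccc1`: 11700 nM
compound 3 `N#Cc1ccccc1COc1ccccc1C(=O)Nc1cccnc1`: 31800 nM

All three were tested in an assay on lysate for inhibition of phosphatidylcholine:ceramide cholinephosphotransferase 2 (Homo sapiens), read by HPLC, with stated times of 30 min and 2 h; on this read-out lower numbers stand for stronger inhibition and higher numbers for weaker inhibition. Compound 3 holds the second highest of the three numbers; its value sits within the scatter of that of compound 1 and is separated from that of compound 2 by a gap beyond the scatter. Among the compounds with values here, the one step that can be read between single-change neighbours is a 4.2-fold lower number from compound 1 to compound 2 (0.62 log units; beyond the scatter), a change on the amide nitrogen and not on the benzyl ether.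

Compound 4 `O=C(Nc1cccnc1)c1ccccc1OCc1cccc(Cl)c1F` differs from compound 3 by 3-chloro-2-fluorophenyl in place of 2-cyanophenyl on a saturated chain carbon bound to an oxygen on an aromatic ring. Within the data shown here, no measured pair isolates a change at this position: compound 1 and compound 3 differ there but also on the amide side, and their values lie within the scatter of each other. With nothing bearing directly on the change, the expected step in this assay is small and without a clear direction, estimated as a 1.3-fold lower number from compound 3 to compound 4 (0.10 log units; within the scatter). Compound 4 is therefore expected to give about 25000 nM, with a range from 8000 nM to 80000 nM.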

Compound 4, half-maximal inhibitory concentration: 3100 nM
The estimate for compound 4 lay 8.1-fold (0.91 log units) above the measured number; the whole stated range lies above it.
By their numbers in this assay, from the lowest: compound 4; then compound 2; then compounds 3 and 1 (each within the scatter of the next).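

In this assay the aryl group on the saturated chain carbon bound to an oxygen on an aromatic ring emerges as a place where the number can move strongly: exchanging 2-cyanophenyl for 3-chloro-2-fluorophenyl gave a 10-fold lower number from compound 3 to compound 4 (1.01 log units; beyond the scatter) with the amide side unchanged. Within the data shown here, the earlier compounds offered a readable step only on the amide nitrogen, so this is the first direct sign that the ether side matters too, and the entering and leaving groups have the same heavy-atom count. Nothing available explains the size of this step.

Still open, from the compounds shown here alone, is whether the chlorine, the fluorine or the loss of the nitrile accounts for the step, as 3-chlorophenyl and 2-fluorophenyl would separate these. Also open, going by these compounds, is whether 3-chloro-2-fluorophenyl gives a similar step alongside pyridin-2-yl or (furan-2-yl)methyl on the amide nitrogen, and how a carboxylic acid at the same place would read.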